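The compounds below may be only part of what the source reports. "The series", "measured", "known", "first", "only" and "open" are said of these compounds alone.

The series shares one core and varies the benzyl group on the triazole and the aryl group on the pyrazole. Compound 1 `COc1cc(Cn2cc(CNC(=O)c3cn(-c4ccccc4)nc3-c3ccccc3)nn2)cc(OC)c1` gives 190 nM in a functional assay on MIA PaCa-2 cells (Homo sapiens) for antiproliferative activity, read by sulforhodamine B assay, with a stated time of 48 h; on this read-out higher numbers stand for weaker inhibition of growth and lower numbers for stronger inhibition of growth. Going by the values given here, compound 2 `O=C(NCc1cn(Cc2ccc(C(F)(F)F)cc2)nn1)c1cn(-c2ccccc2)nc1-c1ccc(Cl)cc1` gives 1100 nM in this assay, and compound 3 `COc1ccc(Cn2cc(CNC(=O)c3cn(-c4ccccc4)nc3-c3ccc(Cl)cc3)nn2)cc1OC` gives 9400 nM, the highest number of the three; the step of an 8.5-fold higher number from compound 2 to compound 3 (0.93 log units; beyond the scatter) covers the only single change measured here. Compound 4 `COc1cc(Cn2cc(CNC(=O)c3cn(-c4ccccc4)nc3-c3ccc(Cl)cc3)nn2)cc(OC)c1` differs from compound 3 by 3,5-dimethoxyphenyl in place of 3,4-dimethoxyphenyl on a saturated chain carbon bound to an aromatic nitrogen. Among the compounds with values here, no measured step covers this exact change. The nearest comparison is compound 1, which carries the same 3,5-dimethoxyphenyl group but a plain phenyl on the core, and whose value 190 nM lies far below that of compound 3; since compound 1 and compound 3 differ in two places, only part of that gap can be ascribed to the benzyl change. Compound 4 is therefore expected to come in lower than compound 3, with a step of roughly a 9.4-fold lower number from compound 3 to compound 4 (0.97 log units; beyond the scatter), and its value in this assay is estimated at 1000 nM, within a range of 200 nM to 5000 nM.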

Compound 4, concentration for 50% growth inhibition: 340 nM
The estimate for compound 4 lay 2.9-fold (0.47 log units) above the measured number, and the stated range covers the measured number.
By their numbers in this assay, from the lowest: compounds 1 and 4 (each within the scatter of the next); then compound 2; then compound 3.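

In this assay, 3,5-dimethoxyphenyl in place of 3,4-dimethoxyphenyl, on a saturated chain carbon bound to an aromatic nitrogen, gives a 28-fold lower number from compound 3 to compound 4 (1.44 log units; beyond the scatter); the two compounds have the same atoms, so the arrangement of the dimethoxyphenyl group alone separates them. Against 4-(trifluoromethyl)phenyl the two dimethoxyphenyl groups now go opposite ways, with a 3.2-fold lower number from compound 2 to compound 4 (0.51 log units; beyond the scatter) set against an 8.5-fold higher number from compound 2 to compound 3 (0.93 log units; beyond the scatter). With 3,5-dimethoxyphenyl held in place, chloro in place of hydrogen on an aromatic carbon gives a 1.8-fold higher number from compound 1 to compound 4 (0.25 log units; within the scatter), which lies within the scatter.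

The data offer no explanation for the large effect of this rearrangement. From the compounds shown here alone, it remains open how a benzyl group carrying an amine or a carboxylic acid would compare, and whether the gap between the two dimethoxyphenyl groups persists on the core of compound 1.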